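The source may report more compounds than this note shows. Statements on the series, on what has been measured and on what is new or still open speak of the compounds shown alone.

Among the measured compounds shown here, compound 2 `COc1cccc(OC)c1[C@@H]1C[C@H](N(C)C)C(=O)N1Cc1ccc(OC(F)(F)F)cc1` holds the higher of the two numbers so far: in a functional assay on CHO cells for antagonist activity at Orexin/Hypocretin receptor type 1 (Homo sapiens), read by FLIPR and calcium flux (a lower number here means a stronger inhibitor, a higher number a weaker inhibitor), compound 2 gives 8720 nM, while compound 1 `CC[C@H]1C[C@@H](c2c(OC)cccc2OC)N(Cc2ccc(OC(F)(F)F)cc2)C1=O` gives 619 nM. For the measured compounds named here, the single measured step, a 14-fold higher number from compound 1 to compound 2 (1.15 log units; beyond the scatter), shows that the dimethylamino group on the saturated ring carbon costs a great deal. Compound 3 `COc1cccc(OC)c1[C@@H]1C[C@H](Cl)C(=O)N1Cc1ccc(OC(F)(F)F)cc1` replaces it: chloro in place of dimethylamino on a saturated ring carbon. Going by the values given here, only that step bears on the change, and since the chloro group is not the dimethylamino group, the expectation is that compound 3 recovers much of the loss, a 5.8-fold lower number from compound 2 to compound 3 (0.76 log units; beyond the scatter). Compound 3 is therefore estimated at 1500 nM, between 400 nM and 6000 nM.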

Compound 3, half-maximal inhibitory concentration: 65 nM
Compound 3: middle estimate off by 23-fold (1.36 log units), on the high side; the measured number lies below the stated range.
By their numbers in this assay, from the lowest: compound 3; then compound 1; then compound 2.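

Chloro in place of dimethylamino brings a 130-fold lower number from compound 2 to compound 3 (2.13 log units; beyond the scatter) on this saturated ring carbon, so a change at this position can do far more than restore what dimethylamino lost. Chloro in place of ethyl brings a 9.5-fold lower number from compound 1 to compound 3 (0.98 log units; beyond the scatter) as well, so the position offers a real gain over ethyl, and chloro gives the lowest number of the three groups. Nothing measured here accounts for these differences.

On these data alone, whether fluoro, bromo or a hydroxyl group on this carbon would match chloro remains open. As far as these compounds go, it is also open whether a primary amine would fare as poorly as dimethylamino.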